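Replacing the aryl group on the ring nitrogen of compound 2

A few compounds are considered here, and "the series" means these few. Any claim that something is new, unique, unknown or untested is made for them only; others in the source may bear on it.

Compound 1 `O=c1ccc2cc(OCc3cc(-c4ccc([N+](=O)[O-])cc4)no3)ccc2o1`: 55800 nM
Compound 2 `COc1ccc(-n2cc(COc3ccc4oc(=O)ccc4c3)nn2)cc1`: 46400 nM
Compound 3 `CC(=O)Nc1ccc(-n2cc(COc3ccc4oc(=O)ccc4c3)nn2)cc1`: 40400 nM

In a functional assay on HL-60 cells (Homo sapiens) for cytotoxicity, read by MTT assay, with a stated time of 48 h (a higher number here means a weaker inhibitor, a lower number a stronger inhibitor), the three measured compounds give numbers that all lie within the usual scatter of one another. Compound 2 gives 46400 nM in this assay, and the number for compound 1 in this assay, 55800 nM, differs from it by an amount no larger than the scatter. Going by the values given here, the one measured step that changes a single place is a 1.1-fold lower number from compound 2 to compound 3 (0.06 log units; within the scatter), which replaces the group on the aromatic ring attached to the ring nitrogen and leaves the number essentially where it was.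

Compound 4 `N#Cc1ccccc1-n1cc(COc2ccc3oc(=O)ccc3c2)nn1` is not yet measured in this assay. It differs from compound 2 by 2-cyanophenyl in place of 4-methoxyphenyl on an aromatic nitrogen. This is the same kind of change as the step from compound 2 to compound 3, which stayed within the scatter, so no step beyond the scatter is expected here. Compound 4 is therefore expected to give about 45000 nM in this assay, with a range from 20000 nM to 100000 nM, meaning an expected step of a 1.0-fold lower number from compound 2 to compound 4 (0.01 log units; within the scatter).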

Compound 4, half-maximal inhibitory concentration: 52100 nM
Beside the measured number, compound 4's estimate is 1.2-fold (0.06 log units) below it; the measured number falls inside the stated range.
By their numbers in this assay, from the lowest: compounds 3, 2, 4 and 1 (each within the scatter of the next).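

In this assay swapping the whole 4-methoxyphenyl for 2-cyanophenyl on the aromatic nitrogen gives a 1.1-fold higher number from compound 2 to compound 4 (0.05 log units; within the scatter) and so leaves the number in place. Compound 3 had exchanged only the group carried by the aryl ring, whereas this step brings in a different aryl group with a nitrile, so the number holds through both kinds of change at this position. Nothing available bears on why the number stays put here.

The compounds shown contain no change at this position that moves the number beyond the scatter, so it remains unknown whether any such change exists. Every compound shown with this ring carries an aryl group on its nitrogen, which leaves open how a cyclohexyl group, a longer alkyl chain, or an aryl group bearing an amine or a carboxylic acid would behave.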